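A few compounds are considered here, and "the series" means these few. Any claim that something is new, unique, unknown or untested is made for them only; others in the source may bear on it.

Of the compounds shown here, three built on a shared core have been tested in a functional assay on MKN-45 cells (Homo sapiens) for cytotoxicity, read by MTT assay, with a stated time of 48 h; a lower number here means a stronger inhibitor, a higher number a weaker inhibitor. Compound 1 `Cc1ccc(C(=O)CSc2nnc(C)n2N2C(=O)c3ccccc3C2=O)cc1` gives > 200000 nM, which is a limit of the assay rather than a number. Compound 2 `C=CCSc1nnc(CC)n1N1C(=O)c2ccccc2C1=O` likewise reaches only the limit > 200000 nM. Compound 3 `C=CCSc1nnc(-c2cc(OC)c(OC)c(OC)c2)n1N1C(=O)c2ccccc2C1=O` also stops at the limit, > 200000 nM. So compound 3 stands exactly where everything measured stands: the limit of > 200000 nM in this assay, at which 3 of the 3 values shown sit. Within the data shown here, no step between two measured compounds can be drawn, since none of the three differs from another in a single place.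

Compound 4 `COc1cc(-c2nnc(SC)n2N2C(=O)c3ccccc3C2=O)cc(OC)c1OC` has not been measured. It differs from compound 3 by hydrogen in place of vinyl on a saturated chain carbon bound to a sulfur, or allylsulfanyl to methylsulfanyl. Among the measured compounds shown here, nothing among the measured compounds shows that a change of this kind moves the read-out, and the three values give only a common limit. The step from compound 3 to compound 4 is therefore expected to be none beyond the scatter, a number no higher from compound 3 to compound 4 (the limit leaves the size open). Compound 4 is estimated at 200000 nM, between 60000 nM and 600000 nM, and the most likely outcome in this assay is once more a limit.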

Compound 4, half-maximal inhibitory concentration: > 200000 nM
Compound 4 was reported as a limit (the forecaster's own chance of this, stated with the estimate: 80%); the middle value sits exactly at the limit.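

No step can be read between compound 3 and compound 4, as both are reported only as limits in this assay. The compounds shown leave open whether any change to the shared core would give a measurable number at all: the limit of > 200000 nM in this assay, at which 4 of the 4 values shown sit.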